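This account rests on a few compounds, and the source may have more. Where it says the series, first, only, none or still open, it means among the compounds named here.

Within the three compounds measured so far, compound 3 `COc1ccc(/C=C/C(=O)c2ccc(NC(=O)CN3CCN(c4cc5c(cc4F)c(=O)c(C(=O)O)cn5C4CC4)CC3)cc2)cc1` stands highest in an assay on isolated protein for inhibition of DNA topoisomerase 1 (Homo sapiens), with a stated time of 30 min, tested at 20 uM (on this read-out higher numbers stand for a stronger effect at the one concentration tested and lower numbers for a weaker effect), at 25.3%. Compound 1 `O=C(CN1CCN(c2cc3c(cc2F)c(=O)c(C(=O)O)cn3C2CC2)CC1)Nc1ccc(C(=O)/C=C/c2ccccc2)cc1` gives 6.4% and compound 2 `O=C(CN1CCN(c2cc3c(cc2F)c(=O)c(C(=O)O)cn3C2CC2)CC1)Nc1ccc(C(=O)/C=C/c2ccccc2Cl)cc1` gives 4.2%; the step of a number 2.2 percentage points lower from compound 1 to compound 2 (within the scatter) shows nothing beyond the scatter, whereas a number 18.9 percentage points higher from compound 1 to compound 3 (beyond the scatter) and a number 21.1 percentage points higher from compound 2 to compound 3 (beyond the scatter) are both modest gains. Compound 4 `COc1ccc(/C=C/C(=O)c2ccc(NC(=O)CN3CCN(c4cc5c(cc4F)c(=O)c(C(=O)O)cn5C4CC4)CC3)cc2)cc1OC` differs from compound 3 by methoxy in place of hydrogen on an aromatic carbon. Among the compounds with values here, the only measured step with a methoxy entering is the one from compound 1 to compound 3, which was modest; no step tests a second methoxy. On that basis the expected change in this assay is small, a number 2.7 percentage points higher from compound 3 to compound 4 (within the scatter), of uncertain direction. Compound 4 is therefore estimated at 28%, with a range from 10% to 48%.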

Compound 4, a percentage reported as inhibition, at one concentration (the size of the read-out at that concentration, not a potency): 2.5%
Compound 4: the middle estimate sits 25.5 percentage points above what was measured; the whole stated range lies above it.
By their numbers in this assay, from the lowest: compounds 4, 2 and 1 (each within the scatter of the next); then compound 3.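

In this assay the methoxy effect is not additive: a second methoxy, ortho to a methoxy group, gives a number 22.8 percentage points lower from compound 3 to compound 4 (beyond the scatter), whereas the first gave a number 18.9 percentage points higher from compound 1 to compound 3 (beyond the scatter). The 3,4-dimethoxyphenyl group therefore leaves no gain over phenyl or 2-chlorophenyl, with a number 3.9 percentage points lower from compound 1 to compound 4 (within the scatter) and a number 1.7 percentage points lower from compound 2 to compound 4 (within the scatter), and among these compounds only the 4-methoxyphenyl group stands out. Nothing measured here bears on the reason for this reversal. As far as these compounds go, it remains open whether the loss is specific to methoxy at this position. A hydroxy group or fluorine there, or a 3-methoxyphenyl group alone, would help separate these possibilities.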